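This account rests on a few compounds, and the source may have more. Where it says the series, first, only, none or still open, it means among the compounds named here.

Working notes on the series. The two measured compounds share a core and differ at both ends. Compound 1 `CN(C)c1ccc(C(=O)N2CCC(n3cncc3-c3ccc(OS(=O)(=O)c4cccc5cnccc45)cc3)CC2)cc1` in an assay on THP-1 cells for antagonist activity at P2X purinoceptor 7 (Homo sapiens), read by ELISA, with a stated time of 30 min (a lower number here means a stronger inhibitor, a higher number a weaker inhibitor), gives 2.19 nM. Compound 2 `N#Cc1cccc(S(=O)(=O)Oc2ccc(-c3cncn3C3CCN(C(=O)c4ccc([N+](=O)[O-])cc4)CC3)cc2)c1` in this assay gives 13 nM, the higher of the two numbers; the gap to compound 1 lies beyond the scatter, but the two compounds differ in more than one place, so no single change can be read from that gap.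

Compound 3 `CN(C)c1ccc(C(=O)N2CCC(n3cncc3-c3ccc(OS(=O)(=O)c4cccc(C#N)c4)cc3)CC2)cc1` is not yet measured. Within the data shown here, it differs from compound 2 by dimethylamino in place of nitro on an aromatic carbon, while the sulfonate end of compound 2 is kept; the amide end of compound 3 is the one found in compound 1.

Expectation: the number for compound 3 should come out lower than that of compound 2, with the step of a 2.6-fold lower number from compound 2 to compound 3 (0.41 log units; beyond the scatter) estimated as modest, since compound 1, which carries the same dimethylamino group, gives 2.19 nM but also differs elsewhere. The estimate for compound 3 is 5 nM, with a range from 1.5 nM to 15 nM.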

Compound 3, half-maximal inhibitory concentration: 10 nM
Beside the measured number, compound 3's estimate is 2.0-fold (0.30 log units) below it; low and high end bracket the measured number.
By their numbers in this assay, from the lowest: compound 1; then compounds 3 and 2 (each within the scatter of the next).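

In this assay the change from 4-nitrophenyl to 4-(dimethylamino)phenyl gives a 1.3-fold lower number from compound 2 to compound 3 (0.11 log units; within the scatter) with 3-cyanophenyl kept on the sulfonyl sulfur, so this assay does not separate the two groups at this place on the amide end. Among these compounds, with the 4-(dimethylamino)phenyl end kept, 3-cyanophenyl in place of isoquinolin-5-yl on the sulfonyl sulfur gives a 4.6-fold higher number from compound 1 to compound 3 (0.66 log units; beyond the scatter) and is the only single change so far that reaches beyond the scatter. No data at hand bear on the cause of either step.

Going by these compounds, whether nitro and dimethylamino also stay within the scatter of each other with isoquinolin-5-yl on the sulfonyl sulfur remains open. Also open, on these data alone, is how a primary amine, a methoxy group or a carboxylic acid would compare at the same place on the amide-end ring.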